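Acetyl to carboxy on the diethylamino compound

This account rests on a few compounds, and the source may have more. Where it says the series, first, only, none or still open, it means among the compounds named here.

Measured in an ADME assay on HaCaT cells (Homo sapiens) for antiproliferative activity, with a stated time of 48 h (on this read-out higher numbers stand for weaker inhibition and lower numbers for stronger inhibition), as follows:
Compound 1 `CC(=O)c1ccc(-c2ccc(N3CCCC3)nn2)cc1` gives > 25000 nM (a limit)
Compound 2 `COC(=O)c1cccc(-c2ccc(-n3cccc3)nn2)c1` gives > 25000 nM (a limit)
Compound 3 `CCN(CC)c1ccc(-c2ccc(C(C)=O)cc2)nn1` gives 20000 nM

Within the data shown here, compound 3 gives 20000 nM as the only true number in the set. The other two entries stand at the limit of > 25000 nM in this assay, at which 2 of the 3 values shown sit, and are limits of the assay, not numbers.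

Compound 4 `CCN(CC)c1ccc(-c2ccc(C(=O)O)cc2)nn1` differs from compound 3 by hydroxy in place of methyl on a carbonyl carbon in one place: hydroxy in place of methyl on a carbonyl carbon, or acetyl to carboxy.

Among the measured compounds shown here, the only measured step is an at least 1.2-fold lower number from compound 1 to compound 3 (0.09 log units; that floor lies within the scatter) and it concerns the diethylamino group, not the acetyl. For the measured compounds named here, no measured step touches the carbonyl carbon, so the series offers no size for this change. No step beyond the scatter is therefore expected in this assay and a result reported only as a limit is about as likely as a number. The expected step is a 1.1-fold higher number from compound 3 to compound 4 (0.04 log units; within the scatter) and no more. Compound 4 is estimated at 22000 nM with 10000 nM to 40000 nM as the expected range.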

Compound 4, half-maximal inhibitory concentration: > 25000 nM
Compound 4 gave a limit, no number; the forecaster's own chance of this, stated with the estimate: 50%; middle value at least 1.1-fold (0.05 log units) from the limit.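

In this assay, among these compounds, hydroxy in place of methyl on a carbonyl carbon gives an at least 1.2-fold higher number from compound 3 to compound 4 (0.09 log units; that floor lies within the scatter), the first measured step at this position. Compound 4 gives > 25000 nM, which is a limit and not a number. The step therefore has only a floor, and the change to carboxy adds no second true number to the series, leaving compound 3 as the only compound with one, while the remaining values stand at one limit: the limit of > 25000 nM in this assay, at which 3 of the 4 values shown sit.

As far as these compounds go, the true value of compound 4 stays open, as does whether acetyl to carboxy reads the same with pyrrolidin-1-yl in place of diethylamino. Also open, from the compounds shown here alone, is whether an amide or a longer chain on the carbonyl carbon gives a number in this assay.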